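Three Amides at the Assay Ceiling, a Fourth to Come

This account rests on a few compounds, and the source may have more. Where it says the series, first, only, none or still open, it means among the compounds named here.

Compound 1 `C=CC1=C(C(=O)Nc2ccc(OCC)cc2)C(c2ccc(OC)cc2)OC1` was measured in a functional assay on HeLa cells (Homo sapiens) for cytotoxicity, read by MTT assay, with a stated time of 24 h; a lower number here means a stronger inhibitor, a higher number a weaker inhibitor. In this assay compound 1 gives > 100000 nM, which is a limit of the assay and not a number.
Compound 2 `C=CC1=C(C(=O)Nc2ccc(C)cc2)C(c2ccc(F)cc2)OC1` was measured in the same way. In this assay compound 2 gives > 100000 nM, again a limit rather than a number.
Compound 3 `C=CC1=C(C(=O)Nc2ccccc2)C(c2ccc(F)cc2)OC1` completes the measured set. In this assay compound 3 gives > 100000 nM, once more a limit and not a number.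

Compound 3 therefore stands at the ceiling of this assay, and the two other values shown sit at the same limit (the limit of > 100000 nM in this assay, at which 3 of the 3 values shown sit). Among the compounds with values here, the only single-point step among the measured compounds, hydrogen in place of methyl on an aromatic carbon, is a step that the two limits leave unreadable from compound 2 to compound 3, and its size cannot be read because both ends are limits.

Compound 4 `C=CC1=C(C(=O)Nc2ccc(OCC)cc2)C(c2ccc(F)cc2)OC1` differs from compound 3 by ethoxy in place of hydrogen on an aromatic carbon of a six-membered aromatic ring of carbon only, para to a large group. No readable step bears on this change, and the same ethoxy group is present in compound 1, which also sits at the limit.

Compound 4 is therefore expected to show a step that the limit leaves unreadable from compound 3 to compound 4 in this assay, which is no step beyond the scatter. The estimate for compound 4 is 150000 nM, with a range from 50000 nM to 500000 nM, and most likely the assay will again report only its limit.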

Compound 4, half-maximal inhibitory concentration: > 100000 nM
Compound 4: no number, only a limit (the forecaster's own chance of this, stated with the estimate: 85%); the middle value is on the limit's open side.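

In this assay compound 4 gives > 100000 nM, which is a limit and not a number. Within the data shown here, no step from compound 1, compound 2 or compound 3 to compound 4 can be read, and all four compounds share one reading: the limit of > 100000 nM in this assay, at which 4 of the 4 values shown sit. The compounds shown leave open what true value any of them has beyond that limit.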